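Swapping a phenethyl arm for a 4-chlorophenyl one

This account rests on a few compounds, and the source may have more. Where it says the series, first, only, none or still open, it means among the compounds named here.

In an assay on COS-7 cells for inhibition of sodium/nucleoside cotransporter 2 (Homo sapiens), read by scintillation counting, in the presence of a further agent that is not named here (on this read-out higher numbers stand for weaker inhibition and lower numbers for stronger inhibition), compound 3 `Nc1ncnc2c1nc(NCCCc1ccccc1)n2[C@@H]1O[C@H](CO)[C@@H](O)[C@H]1O` gives 536000 nM, the highest of the two numbers measured. Compound 2 `Nc1ncnc2c1nc(NCc1cccc(Cl)c1)n2[C@@H]1O[C@H](CO)[C@@H](O)[C@H]1O` gives 5400 nM in this assay, and the pair shows a 99-fold higher number from compound 2 to compound 3 (2.00 log units; beyond the scatter). Compound 1 `COc1ccccc1CNc1nc2c(N)ncnc2n1[C@@H]1O[C@H](CO)[C@@H](O)[C@H]1O` gives > 100000 nM in this assay, a value that is only a limit of the assay (the limit of > 100000 nM in this assay, at which 1 of the 3 values shown sits). The unmeasured compound 4 `Nc1ncnc2c1nc(NCc1ccc(Cl)cc1)n2[C@@H]1O[C@H](CO)[C@@H](O)[C@H]1O` differs from compound 3 by 4-chlorophenyl in place of phenethyl on a saturated chain carbon bound to a nitrogen on an aromatic ring. This change is nearly the reverse of a 99-fold higher number from compound 2 to compound 3 (2.00 log units; beyond the scatter), though the ring now carries its chlorine as 4-chlorophenyl rather than 3-chlorophenyl; an at least 18-fold lower number from compound 1 to compound 2 (1.26 log units; beyond the scatter) also shows a chlorophenyl giving a lower number. A large drop is therefore expected, a 54-fold lower number from compound 3 to compound 4 (1.73 log units; beyond the scatter). Compound 4 is estimated at 10000 nM, between 2000 nM and 100000 nM.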

Compound 4, half-maximal inhibitory concentration: 11000 nM
Compound 4: the middle estimate sits 1.1-fold (0.04 log units) below what was measured; measured number inside the range.
By their numbers in this assay, from the lowest: compound 2; then compound 4; then compound 3.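

The lower number is not tied to 3-chlorophenyl: 4-chlorophenyl also gives stronger inhibition than phenethyl, with a 49-fold lower number from compound 3 to compound 4 (1.69 log units; beyond the scatter) as the step. Exchanging 3-chlorophenyl for 4-chlorophenyl matters far less, with a 2.0-fold higher number from compound 2 to compound 4 (0.31 log units; beyond the scatter) as its modest step. Against 2-methoxyphenyl, 4-chlorophenyl also shows an at least 9.0-fold lower number from compound 1 to compound 4 (0.95 log units; beyond the scatter) as its step, but compound 1 rests on a limit of the assay: the limit of > 100000 nM in this assay, at which 1 of the 4 values shown sits.

As far as these compounds go, whether an amine or a carboxylic acid in place of the chlorine would keep the number this low stays open. So does what a longer chain carrying 4-chlorophenyl would give.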